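Notes on a 4-fluorobenzyl swap from compound 1

The compounds below may be only part of what the source reports. "The series", "measured", "known", "first", "only" and "open" are said of these compounds alone.

- compound 1 `COc1cc(OC)c(/C=C(/SCc2ccc(Cl)c(Cl)c2)C(=O)c2ccc(Cl)cc2)c(OC)c1` gives 10000 nM
- compound 2 `Cc1ccc(S/C(=C/c2ccc(Oc3ccccc3)cc2)C(=O)c2ccc(Cl)cc2)cc1` gives 10000 nM
- compound 3 `COc1ccc(/C=C(\C(=O)c2ccc(Cl)cc2)S(=O)(=O)Cc2ccccc2Cl)cc1` gives 50000 nM

All three values come from a functional assay on DU-145 cells (Homo sapiens) for inhibition, read by trypan blue exclusion, with a stated time of 96 h (on this read-out lower numbers stand for stronger inhibition of growth and higher numbers for weaker inhibition of growth), and compound 1 stands level with compound 2 at the lowest number of the three, while compound 3 sits higher, beyond the scatter. Compound 4 `COc1cc(OC)c(/C=C(/SCc2ccc(F)cc2)C(=O)c2ccc(Cl)cc2)c(OC)c1` has not yet been measured. It differs from compound 1 by 4-fluorophenyl in place of 3,4-dichlorophenyl on a saturated chain carbon bound to a sulfur with 4-fluorophenyl in place of 3,4-dichlorophenyl on a saturated chain carbon bound to a sulfur. Going by the values given here, no measured pair isolates this change, so the expectation rests on compound 1 (10000 nM) alone. In this assay the expected size is no change at the digits printed from compound 1 to compound 4 (within the scatter) and no step beyond the scatter is expected. The estimated value for compound 4 is 10000 nM with an expected range from 2500 nM to 40000 nM until the measurement arrives.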

Compound 4, concentration for 50% growth inhibition: 10000 nM
Estimate against measurement, compound 4: no gap at the digits printed, and the stated range covers the measured number.
By their numbers in this assay, from the lowest: compounds 1, 2 and 4 (each within the scatter of the next); then compound 3.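

In this assay, going by these compounds alone, 4-fluorophenyl in place of 3,4-dichlorophenyl on a saturated chain carbon bound to a sulfur gives no change at the digits printed from compound 1 to compound 4 (within the scatter), the first step that isolates a single place. At this position, then, the two halogenated groups read alike, and the two chlorines are not required for the number seen with compound 1. No measurement shown bears on why the two groups read alike.

Open, on these data alone, is whether an amine, a carboxylic acid or a longer chain at this position would give a step beyond the scatter.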